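A methoxy added to compound 3

The source may report more compounds than this note shows. Statements on the series, on what has been measured and on what is new or still open speak of the compounds shown alone.

Among the compounds with values here, the values measured so far in a functional assay on CNE-2 cells (Homo sapiens) for antiproliferative activity, read by sulforhodamine B assay, with a stated time of 48 h (a lower number here means a stronger inhibitor, a higher number a weaker inhibitor), are these.
- Compound 1 `COc1ccc(/C=C/C(=O)c2ccccc2-c2cccc(F)c2)cc1O` gives 17 nM
- Compound 2 `COc1ccc(C(=O)/C=C/c2ccccc2-c2ccc(F)cc2)cc1` gives 9000 nM
- Compound 3 `COc1ccc(C(=O)/C=C/c2ccccc2-c2ccc(F)nc2)cc1` gives 13000 nM

In this assay compound 3 stands at the weak end of this small set, within the scatter of compound 2 and far from compound 1. The next compound, compound 4 `COc1ccc(C(=O)/C=C/c2ccccc2-c2ccc(F)nc2)cc1OC`, carries methoxy in place of hydrogen on an aromatic carbon, ortho to a methoxy group and meta to a large group: methoxy in place of hydrogen on an aromatic carbon is the whole change.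

Little in the data bears directly on it. Within the data shown here, the only measured single-place step, a 1.4-fold higher number from compound 2 to compound 3 (0.16 log units; within the scatter), lies within the scatter, but it concerns a different part of the molecule. Compound 1 reaches 17 nM but differs from compound 3 in several places at once, so it does not show what this methoxy alone does. No shift beyond the scatter is therefore expected, with at most a slight move towards a lower number. The expected change is a 1.4-fold lower number from compound 3 to compound 4 (0.16 log units; within the scatter).

For compound 4 the estimated value is 9000 nM, with an expected range from 3000 nM to 27000 nM.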

Compound 4, half-maximal inhibitory concentration: 17000 nM
Estimate against measurement, compound 4: 1.9-fold (0.28 log units) below; the range from low to high includes it.
By their numbers in this assay, from the lowest: compound 1; then compounds 2, 3 and 4 (each within the scatter of the next).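

Within the data shown here, with compound 3 as the starting point, the new step gives the first reading at this ring: methoxy in place of hydrogen on an aromatic carbon, ortho to a methoxy group and meta to a large group, produces a 1.3-fold higher number from compound 3 to compound 4 (0.12 log units; within the scatter) in this assay. The two compounds therefore cannot be told apart, and in this setting the added methoxy leaves the antiproliferative read-out without any shift beyond the scatter, an outcome that the earlier step, which concerned a different part of the molecule, could not show. No measured information accompanies this result that could account for it.

From the compounds shown here alone, whether a hydroxy group, an amine or a longer chain such as ethoxy at this same place would shift the number beyond the scatter remains open, as does the effect of this methoxy on a more active parent. Among these compounds, no single-place step links compound 1, at 17 nM in this assay, to the other compounds.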